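Methyl Removal in Two Closely Related Cores

The source may hold more compounds than are shown below. What is called first, only, known or untested is meant among the compounds shown, and "the series" means these compounds.

Compound 1 `N/C(=N\NC(=S)N1CCOCC1)c1ccccn1` was tested in a functional assay on A-431 cells (Homo sapiens) for cytotoxicity, read by MTT assay, with a stated time of 72 h, tested at 10 uM (on this read-out higher numbers stand for more inhibition of growth at the one concentration tested and lower numbers for less inhibition of growth), where compound 1 gives 69.4%. Compound 2 `Cc1ccnc(/C(N)=N/NC(=S)N2CCOCC2)c1` carries a methyl, and in this assay compound 2 gives 62%. Compound 3 `Cc1cccc(/C(N)=N/NC(=S)N2CCCC2)n1` rests on a different core; the difference between the two cores is not broken down here. In this assay compound 3 gives 67.6%. From compound 2 to compound 1 the change is hydrogen in place of methyl on an aromatic carbon, and the step is a number 7.4 percentage points higher from compound 2 to compound 1 (within the scatter). The same kind of change, (hydrogen in place of methyl on an aromatic carbon), leads to compound 4 `N/C(=N\NC(=S)N1CCCC1)c1ccccn1`; the surroundings differ, the methyl of compound 2 sitting opposite the ring nitrogen while that of compound 3 sits next to the ring nitrogen. On the strength of the step of a number 7.4 percentage points higher from compound 2 to compound 1 (within the scatter), which lies within the scatter, the expected step of a number 2.4 percentage points higher from compound 3 to compound 4 (within the scatter) is small as well. Compound 4 is estimated at 70%, between 58% and 80%.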

Compound 4, percent growth inhibition at one concentration: 77.2%
Compound 4: middle estimate off by 7.2 percentage points, on the low side; the measured number falls inside the stated range.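

Carried to the second core, hydrogen in place of methyl on an aromatic carbon gives a number 9.6 percentage points higher from compound 3 to compound 4 (within the scatter), and the two instances of this change agree in this assay: the same change on two cores in this assay, a number 7.4 percentage points higher (within the scatter) from compound 2 to compound 1 and a number 9.6 percentage points higher (within the scatter) from compound 3 to compound 4, 2.2 percentage points apart, within the scatter of two such steps

Each step lies within the scatter, so the change can be said to carry across these two cores only within what the assay can separate; this does not show that removing the methyl improves growth inhibition, and two pairs set no rule for the series. Pyrrolidin-1-yl in place of morpholin-4-yl on a thiocarbonyl carbon gives a number 7.8 percentage points higher from compound 1 to compound 4 (within the scatter), which likewise cannot be told from the scatter.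

The compounds shown leave open whether an ethyl or a chlorine in place of the methyl, or an open-chain amine such as diethylamine in place of the pyrrolidin-1-yl, would give a step beyond the scatter.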